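The source may hold more compounds than are shown below. What is called first, only, known or untested is meant among the compounds shown, and "the series" means these compounds.

In a functional assay on cells (Cancer cell lines, Homo sapiens) for inhibition, read by MTT assay, with a stated time of 48 h (a higher number here means a weaker inhibitor, a lower number a stronger inhibitor), compound 1 `O=C(/C=C/c1ccc(F)cc1)NNC(=O)c1ccc2c(c1)OCCO2` gives 990 nM and is the stronger inhibitor of the measured pair. Compound 2 `Cc1cccc(/C=C/C(=O)NNC(=O)c2ccc3c(c2)OCCO3)c1` gives 2890 nM and holds the higher of the two numbers, which marks it as the weaker inhibitor. The move to compound 3 `COc1cccc(/C=C/C(=O)NNC(=O)c2ccc3c(c2)OCCO3)c1` is methoxy in place of methyl on an aromatic carbon with methoxy in place of methyl on an aromatic carbon, meta to a large group. For the measured compounds named here, only one measured step bears on this, a 2.9-fold higher number from compound 1 to compound 2 (0.47 log units; beyond the scatter) in which 3-methylphenyl replaced 4-fluorophenyl. That modest step involved no methoxy, so it offers a rough guide to size but none to direction. A step no larger is expected here, leaning slightly towards a lower number. The estimate amounts to a 1.4-fold lower number from compound 2 to compound 3 (0.16 log units; within the scatter) and so no clear change is expected in this assay from this swap. Compound 3 is estimated at 2000 nM with an expected range from 700 nM to 6000 nM when measured.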

Compound 3, half-maximal inhibitory concentration: 170 nM
For compound 3 the middle estimate is 12-fold (1.07 log units) above the measured one; the measured number lies below the stated range.
By their numbers in this assay, from the lowest: compound 3; then compound 1; then compound 2.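

In this assay, the change on this aromatic carbon, meta to a large group, proved far from neutral: methoxy in place of methyl gave a large step (a 17-fold lower number from compound 2 to compound 3 (1.23 log units; beyond the scatter)), although the swap adds only one oxygen and one hydrogen-bond acceptor. The 3-methoxyphenyl group also moved the number past that of the 4-fluorophenyl group (a 5.8-fold lower number from compound 1 to compound 3 (0.77 log units; beyond the scatter)), whereas 3-methylphenyl had moved it the other way (a 2.9-fold higher number from compound 1 to compound 2 (0.47 log units; beyond the scatter)), so the group at this end of the chain can shift the number in either direction from compound 1. Nothing available gives a measured reason for the size of these steps.

The compounds shown leave open whether an ethoxy or a hydroxy group on the same carbon would keep the lower number. They also leave open whether an amine there would do the same.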